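The compounds below may be only part of what the source reports. "The series", "measured", "known", "first", "only" and "open" are said of these compounds alone.

Measured compounds:
- compound 1 `COc1ccccc1-c1nccc2[nH]c(C(C)(C)O)cc12`: "not determined" (no result reported)
- compound 2 `CCSc1ccc(-c2nccc3[nH]c(C(C)(C)O)cc23)cc1`: 17200 nM

For the measured compounds named here, in an ADME assay on U2OS cells (Homo sapiens) for cytotoxicity (a lower number here means that less compound is tolerated, a higher number that more compound is tolerated), compound 2 gives 17200 nM, and this is the only number available. It has no measured neighbour, so it cannot be ranked as high or low within the series. For compound 1 the entry reads "not determined" (no result reported), which offers no comparison.

The next compound to be tested is compound 3 `CC(C)(O)c1cc2c(-c3ccc(F)cc3)nccc2[nH]1`, which keeps the shared core and changes one substituent: fluoro in place of ethylsulfanyl on an aromatic carbon. It has fluoro in place of ethylsulfanyl on an aromatic carbon, para to a large group. Going by the values given here, no pair of measured compounds shows what a change of this kind does in this assay, so any expectation rests on a single anchor and remains loose. With compound 2 at 17200 nM as that anchor, a modest shift towards more compound tolerated seems the likeliest outcome, though one within the scatter would be no surprise. The estimated change is a 1.5-fold higher number from compound 2 to compound 3 (0.18 log units; within the scatter). For compound 3 the expected value is 26000 nM, with an estimated range of 10000 nM to 70000 nM.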

Compound 3, half-maximal cytotoxic concentration: 93600 nM
Compound 3: the middle estimate sits 3.6-fold (0.56 log units) below what was measured; the measured number lies above the stated range.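

For the compounds shown here, the step to compound 3 gives the first reading of what a change at this position does: on the aromatic carbon para to a large group, fluoro in place of ethylsulfanyl brings a 5.4-fold higher number from compound 2 to compound 3 (0.74 log units; beyond the scatter) in this assay. With the shared core untouched, this one substituent is enough to move the read-out beyond the usual scatter, and more compound is tolerated with fluoro than with ethylsulfanyl at this place. The swap removes the sulfur, the chain carbons and a hydrogen-bond acceptor all at once, and nothing measured here tells these differences apart or bears on why the number moves.

From the compounds shown here alone, whether the rise belongs to fluoro itself or to the loss of ethylsulfanyl remains open, and a plain hydrogen, an amine or a carboxylic acid at the same place would help to separate the two. Going by these compounds, it also remains open whether the step carries over to other substitution on the aromatic ring, since compound 1 reads "not determined" (no result reported) and offers no comparison.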